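Diarylamine Series: Methoxyphenyl to Dichlorophenyl in Cytotoxicity

A few compounds are considered here, and "the series" means these few. Any claim that something is new, unique, unknown or untested is made for them only; others in the source may bear on it.

Compound 1, `C=C[C@@](C)(/C=C/c1ccc(O)c(/C=C/C(N)=O)c1)CCC=C(C)C`: > 36600 nM
Compound 2, `C=C[C@@](C)(/C=C/c1ccc(Nc2ccc(OC)cc2)cc1)CCC=C(C)C`: > 36600 nM

In an ADME assay on HEK293 cells (Homo sapiens) for cytotoxicity, with a stated time of 72 h (on this read-out higher numbers stand for an effect only at larger amounts of compound and lower numbers for an effect already at smaller amounts), compound 1 reaches only a limit, > 36600 nM. Compound 2 likewise gives only a limit, > 36600 nM. Both readings sit at the limit of > 36600 nM in this assay, at which 2 of the 2 values shown sit, so compound 2 stands where everything measured here stands, with no number to set it against. Compound 3, `C=C[C@@](C)(/C=C/c1ccc(Nc2ccc(Cl)c(Cl)c2)cc1)CCC=C(C)C`, carries 3,4-dichlorophenyl in place of 4-methoxyphenyl on a nitrogen on an aromatic ring. Among the measured compounds shown here, no measured pair covers this change. For a number no higher from compound 2 to compound 3 (the limit leaves the size open) no shift beyond the usual scatter is expected. Compound 3 is expected most likely to return a limit again, with an estimate of 36600 nM, ranging from 15000 nM to 100000 nM.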

Compound 3, half-maximal effective concentration: > 36600 nM
Compound 3: a limit, no number (the forecaster's own chance of this, stated with the estimate: 75%); the middle value sits exactly at the limit.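

Compound 3 gives only a limit, > 36600 nM, so no step can be read between compound 2 and compound 3. The compounds shown leave open how 3,4-dichlorophenyl and 4-methoxyphenyl compare in this assay.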